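The source may hold more compounds than are shown below. What is called first, only, known or untested is meant among the compounds shown, and "the series" means these compounds.

Compound 3, whose structure is `C=C/C=C\C(C)C(OC(N)=O)[C@@H](C)[C@H](O)[C@@H](C)C/C=C\C(C)[C@@H](O)[C@@H](C)/C=C\C(O)C[C@@H]1OC(=O)C(C)[C@@H](O)[C@H]1C`, is the starting point of this step. In a functional assay on A549 cells (Homo sapiens) for inhibition (on this read-out higher numbers stand for weaker inhibition and lower numbers for stronger inhibition), compound 3 gives 7.8 nM, which places it second highest among the three numbers measured. Compound 1, of structure `C=C/C=C\C(C)C(OC(N)=O)[C@@H](C)[C@H](O)C(C)C/C(C)=C\C(C)[C@@H](O)[C@@H](C)/C=C\C(C[C@@H]1OC(=O)[C@H](C)[C@@H](OC(C)=O)[C@H]1C)OC(C)=O`, gives 0.8 nM in this assay, a lower number that lies beyond the scatter from compound 3. Compound 2, of structure `C=C/C=C\C(C)C(OC(N)=O)[C@@H](C)[C@H](O)C(C)C/C(C)=C\C(C)[C@@H](OC(C)=O)[C@@H](C)/C=C\C(O)C[C@@H]1OC(=O)[C@H](C)[C@@H](OC(C)=O)[C@H]1C`, gives 164 nM in this assay, a higher number that also lies beyond the scatter from compound 3. Compound 4, of structure `C=C/C=C\C(C)C(OC(N)=O)[C@@H](C)[C@H](O)[C@@H](C)C/C=C/C(C)[C@@H](O)[C@@H](C)/C=C\C(O)C[C@@H]1OC(=O)C(C)[C@@H](O)[C@H]1C`, has not yet been measured. It differs from compound 3 only in one stereo element: the two compounds have the same atoms and bonds; at least one stereo element is drawn with a configuration in one of them and without one in the other: 1 of 16 stereo elements differ; a double bond is drawn Z in compound 3 and E in compound 4. No measured pair shows what the change of this double bond from Z to E does, so the direction of the step rests on no shown comparison. A step toward a higher number, meaning weaker inhibition, is expected for compound 4, and the step from compound 3 to compound 4 is estimated as a 5.1-fold higher number from compound 3 to compound 4 (0.71 log units; beyond the scatter). For compound 4 the expected value in this assay is 40 nM, with a range from 8 nM to 300 nM.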

Compound 4, half-maximal inhibitory concentration: 485 nM
Estimate against measurement, compound 4: 12-fold (1.08 log units) below, outside the stated range (above it).
By their numbers in this assay, from the lowest: compound 1; then compound 3; then compound 2; then compound 4.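

Changing this double bond from Z to E gives a 62-fold higher number from compound 3 to compound 4 (1.79 log units; beyond the scatter) in this assay, although no atom or bond is added or removed. The earlier compounds shown here differed from one another in several places, so none of them could isolate this double bond; this pair shows that its geometry alone can separate two compounds by a wide margin, with the Z form giving the stronger inhibition. One caution applies to how the step is read: the fact that one of compounds 3 and 4 is drawn with a defined configuration and the other without, at the place where they differ

The compounds shown leave open whether the same change has a comparable effect in compounds carrying the acetate groups of compound 1 and compound 2. They also leave open how an alkyne or a cyclopropane in place of this double bond would compare with either geometry.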